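Working notes on the step to compound 3

The compounds below may be only part of what the source reports. "The series", "measured", "known", "first", "only" and "open" are said of these compounds alone.

Compound 1 `COc1cc(CNC(=O)CCCC/C=C/C(C)C)ccc1OCCCCCOc1ccc(-c2cc(=S)ss2)cc1`: > 50000 nM (a limit)
Compound 2 `COc1cc(CNC(=O)CCCCCCC(C)C)ccc1OCCCCCOc1ccc(C(N)=S)cc1`: 49300 nM

Within the data shown here, in a functional assay on MCF7 cells (Homo sapiens) for antiproliferative activity, read by MTT assay, with a stated time of 48 h (on this read-out higher numbers stand for weaker inhibition and lower numbers for stronger inhibition), compound 2 gives 49300 nM, the only actual number so far. Compound 1 gives > 50000 nM, which is a limit of the assay and not a number. Compound 2 therefore cannot yet be ranked against a second measured value.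

The next compound is compound 3 `COc1cc(CNC(=O)CCCCCCC(C)C)ccc1OCCCCCOc1ccc(-c2cc(=S)ss2)cc1`. Its change from compound 2 is a group of 6 heavy atoms (3 carbon, 3 sulfur; one five-membered aromatic ring with 2 hetero atoms) in place of a group of 3 heavy atoms (1 carbon, 1 nitrogen, 1 sulfur; no ring), on an aromatic carbon, para to a large group. Among the measured compounds shown here, no measured step between two compounds is available to size this change. The expectation is therefore no shift beyond the usual scatter in this assay, in either direction. It rests on compound 2 at 49300 nM. For the measured compounds named here, it also rests on compound 1, the only tested compound that already carries the entering group, at the limit of > 50000 nM in this assay, at which 1 of the 2 values shown sits. The expected step of a 1.0-fold higher number from compound 2 to compound 3 (0.01 log units; within the scatter) is estimated to lie within the scatter. For compound 3 the estimated value is 50000 nM, with an expected range of 20000 nM to 100000 nM.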

Compound 3, half-maximal inhibitory concentration: 48700 nM
Estimate against measurement, compound 3: 1.0-fold (0.01 log units) above, and the stated range covers the measured number.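

In this assay the exchange on an aromatic carbon, para to a large group, gives a 1.0-fold lower number from compound 2 to compound 3 (0.01 log units; within the scatter) and so provides the first measured size for a change at this position. On this read-out the group with one five-membered aromatic ring and 0 hydrogen-bond donors cannot be told apart from the ring-free group with 1 hydrogen-bond donor. Compound 1 gives > 50000 nM as a limit of the assay and not a number, so isopentyl in place of 3-methylbut-1-en-1-yl on the saturated chain carbon yields an at least 1.0-fold lower number from compound 1 to compound 3 (0.01 log units; that floor lies within the scatter) and that step has only a floor, because one of its ends sits at a limit: the limit of > 50000 nM in this assay, at which 1 of the 3 values shown sits.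

On these data alone, what an amine or a carboxylic acid on this aromatic carbon would give remains open, so it is unknown whether any group at this position moves the number beyond the scatter. Also open, as far as these compounds go, is what a longer chain in place of isopentyl would give with the entering ring group held constant, and whether the saturated chain carbon matters at all on this read-out.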